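Aryl group at the core: phenyl in place of benzofuran

The compounds below may be only part of what the source reports. "The series", "measured", "known", "first", "only" and "open" are said of these compounds alone.

Compound 1 `O=c1[nH]cnc2c1c(-c1ccoc1)cn2[C@@H]1O[C@H](CO)[C@@H](O)[C@H]1O` gives > 100000 nM in an ADME assay on BJ cells (Homo sapiens), read by MTT assay, with a stated time of 72 h (on this read-out lower numbers stand for stronger inhibition and higher numbers for weaker inhibition), a limit of the assay rather than a number.
Compound 2 `O=c1[nH]cnc2c1c(-c1ccsc1)cn2[C@@H]1O[C@H](CO)[C@@H](O)[C@H]1O` gives > 100000 nM in this assay, again a limit and not a number.
Compound 3 `O=c1[nH]cnc2c1c(-c1cc3ccccc3o1)cn2[C@@H]1O[C@H](CO)[C@@H](O)[C@H]1O` gives 62700 nM in this assay.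

Going by the values given here, compound 3 stands as the only measured number in this assay; the other two values are limits. The step from compound 1 to compound 2 is unreadable because the limit of > 100000 nM in this assay, at which 2 of the 3 values shown sit, holds both values. The steps toward compound 3 read as an at least 1.5-fold lower number from compound 1 to compound 3 (0.20 log units; that floor lies within the scatter) and an at least 1.5-fold lower number from compound 2 to compound 3 (0.20 log units; that floor lies within the scatter), each only a floor that sits within the scatter.

Compound 4 `O=c1[nH]cnc2c1c(-c1ccccc1)cn2[C@@H]1O[C@H](CO)[C@@H](O)[C@H]1O` has not yet been measured. The change is phenyl in place of 1-benzofuran-2-yl on an aromatic carbon. The two readable steps both show the 1-benzofuran-2-yl group giving a lower number than a five-membered aromatic ring; phenyl is a smaller, single six-membered ring, so a return toward the higher numbers of compound 1 and compound 2 is expected, though the floors cannot fix its size. For compound 4 the estimate in this assay is 100000 nM, with a range from 30000 nM to 300000 nM; the expected step is a 1.6-fold higher number from compound 3 to compound 4 (0.20 log units; within the scatter).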

Compound 4, half-maximal inhibitory concentration: > 100000 nM
Compound 4: only a limit was reported; the forecaster's own chance of this, stated with the estimate: 50%; the middle value lies on the limit itself.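

In this assay, phenyl in place of 1-benzofuran-2-yl on this aromatic carbon gives an at least 1.5-fold higher number from compound 3 to compound 4 (0.20 log units; that floor lies within the scatter). A single six-membered aromatic ring of carbon only therefore joins furan-3-yl and thiophen-3-yl at the limit, and among the four compounds only the fused 1-benzofuran-2-yl group gives a measured number. The steps from compound 1 and from compound 2 to compound 4 cannot be read, because both ends of each step sit on one limit: the limit of > 100000 nM in this assay, at which 3 of the 4 values shown sit.

The compounds shown do not separate the second aromatic ring of 1-benzofuran-2-yl from its ring oxygen, and the floors do not show whether any real difference exists at this position. Also open, from the compounds shown here alone, is how a naphthyl group, or an amine or a carboxylic acid on the phenyl ring, would read in this assay.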